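The source may hold more compounds than are shown below. What is called first, only, known or untested is meant among the compounds shown, and "the series" means these compounds.

Among the measured compounds shown here, in an ADME assay (liver) for metabolic stability, with Liver microsome (Homo sapiens) as the target, read by LC-MS, using microsomes, with a stated time of 1 h, tested at 5 uM (a higher number here means that more of the compound is left, a lower number that less of the compound is left), compound 2 `Cc1nc(-c2ccccc2F)c(C(=O)N2CCN(c3cc(Cl)cc(Cl)c3)CC2)o1` gives 82.3%, the highest of the three numbers so far. Compound 3 `Cc1nc(-c2ccc(F)cc2)c(C(=O)N2CCN(c3cc(Cl)cc(Cl)c3)CC2)o1` gives 71.8%. Compound 4 `COc1cc(OC)cc(N2CCN(C(=O)c3oc(C)nc3-c3ccccc3F)CC2)c1` is still unmeasured and differs from compound 2 by one change: 3,5-dimethoxyphenyl in place of 3,5-dichlorophenyl on an amine nitrogen in a ring. For the measured compounds named here, the only measured single-place step, a number 10.5 percentage points lower from compound 2 to compound 3 (beyond the scatter), is modest and sits at a different place, so it offers no direct guide to this change. Compound 1 `Cc1nc(-c2ccccc2)c(C(=O)N2CCN(c3cccc(Cl)c3)CC2)o1` differs from compound 2 at this same place and at a second one, and compound 1 gives 13.5%, so a wide range of numbers is possible. A sizeable fall is expected, estimated as a number 32.3 percentage points lower from compound 2 to compound 4 (beyond the scatter). For compound 4 the estimated value is 50%, with an expected range from 25% to 75%.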

Compound 4, percent of the compound remaining: 15%
For compound 4 the middle estimate is 35 percentage points above the measured one; the measured number lies below the stated range.
By their numbers in this assay, from the lowest: compounds 1 and 4 (each within the scatter of the next); then compound 3; then compound 2.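

The place on the ring nitrogen had not been tested by a single change before, and compounds 2 and 4 now isolate it. In this assay, 3,5-dimethoxyphenyl in place of 3,5-dichlorophenyl gives a number 67.3 percentage points lower from compound 2 to compound 4 (beyond the scatter) with the rest of the molecule unchanged. The group at this place alone can therefore make a large difference to how much compound remains.

From the compounds shown here alone, it remains open how a phenyl bearing trifluoromethyl or nitrile groups would behave in place of 3,5-dichlorophenyl. Nothing shown here explains why this step is so large.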